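A few compounds are considered here, and "the series" means these few. Any claim that something is new, unique, unknown or untested is made for them only; others in the source may bear on it.

Working notes on the series. Compound 1 `Cc1ccc(S/C(=C/c2c[nH]c3ccccc23)C(=O)c2ccc(Br)cc2)cc1` gives 10000 nM in a functional assay on DU-145 cells (Homo sapiens) for inhibition, read by trypan blue exclusion, with a stated time of 96 h; on this read-out lower numbers stand for stronger inhibition of growth and higher numbers for weaker inhibition of growth. Compound 2 `COc1ccc(/C=C(/Sc2ccc(C)cc2)C(=O)c2ccc(Cl)cc2)cc1` gives 1000 nM in this assay. For compound 3 `Cc1ccc(S/C(=C/c2ccc(C)s2)C(=O)c2ccc(Br)cc2)cc1` only a limit of the assay is known, > 100000 nM in this assay, so compound 3 stands at the weak end of the numbers shown, at the limit of > 100000 nM in this assay, at which 1 of the 3 values shown sits. Among the compounds with values here, the one measured step that reaches compound 3 is an at least 10-fold higher number from compound 1 to compound 3 (1.00 log units; beyond the scatter), which moves from a number to a limit. Compound 4 `COc1ccc(/C=C(/Sc2ccc(C)cc2)C(=O)c2ccc(Br)cc2)cc1` is not yet measured in this assay. Its difference from compound 3 is 4-methoxyphenyl in place of 5-methylthiophen-2-yl on a double-bonded chain carbon bound to a double-bonded chain carbon. The change runs opposite to the measured step in kind, taking the five-membered ring out again and bringing in a six-membered aromatic ring, the group that compound 2 carries at the same place with 1000 nM. The step of an at least 50-fold lower number from compound 3 to compound 4 (1.69 log units; beyond the scatter) is therefore expected to return a measurable number, with at least a modest gain. The estimate for compound 4 is 2000 nM, expected to fall between 500 nM and 8000 nM.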

Compound 4, concentration for 50% growth inhibition: 50000 nM
Estimate against measurement, compound 4: 25-fold (1.40 log units) below; the measured number lies above the stated range.
By their numbers in this assay, from the lowest: compound 2; then compound 1; then compound 4. At a limit, above all of these: compound 3.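

With bromo held constant, the 4-methoxyphenyl group does not by itself carry the activity seen in compound 2: a 50-fold higher number from compound 2 to compound 4 (1.70 log units; beyond the scatter), so at this aromatic carbon the change from chloro to bromo counts for much in this pair. Among the bromo compounds, 1H-indol-3-yl gives the lower number on the double-bonded chain carbon, with a 5.0-fold higher number from compound 1 to compound 4 (0.70 log units; beyond the scatter). With an at least 2.0-fold lower number from compound 3 to compound 4 (0.30 log units; that floor lies within the scatter), no order of 4-methoxyphenyl and 5-methylthiophen-2-yl can be claimed, and compound 3 stays a limit of the assay: the limit of > 100000 nM in this assay, at which 1 of the 4 values shown sits.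

On these data alone, whether the gap between chloro and bromo also holds with 1H-indol-3-yl on the chain carbon stays open, as does the reading for fluoro on the same aromatic carbon. Also open, as far as these compounds go, is how an amine or a carboxylic acid in place of the methoxy group would read.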